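Chain amine change carried from one core to another

The compounds below may be only part of what the source reports. "The series", "measured", "known", "first", "only" and "open" are said of these compounds alone.

The shared core is represented by compound 1 `CCN(CC)CCn1c(N)c(-c2nc3ccccc3[nH]2)c2nc(C#N)c(C#N)nc21`, which in a functional assay on K562 cells (Homo sapiens) for antiproliferative activity, read by MTT assay, with a stated time of 48 h (a higher number here means a weaker inhibitor, a lower number a stronger inhibitor), gives 2490 nM. Compound 2 `CN(C)CCCn1c(N)c(-c2nc3ccccc3[nH]2)c2nc(C#N)c(C#N)nc21` carries (dimethylamino)methyl in place of diethylamino on a saturated chain carbon, two bonds along the chain from an aromatic nitrogen, and in this assay compound 2 gives 1730 nM; the result is a 1.4-fold lower number from compound 1 to compound 2 (0.16 log units; within the scatter). Compound 3 `CCN(CC)CCCn1c(N)c(-c2nc3ccccc3n2C)c2nc(C#N)c(C#N)nc21` has a different core, and the difference between the two cores is not broken down here; in this assay compound 3 gives 3270 nM. All three values lie within the scatter of one another, so no order among them can be claimed.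

Compound 4 `CN(C)CCCCn1c(N)c(-c2nc3ccccc3n2C)c2nc(C#N)c(C#N)nc21` is not yet measured. Relative to compound 3 it carries (dimethylamino)methyl in place of diethylamino on a saturated chain carbon, three bonds along the chain from an aromatic nitrogen. For the measured compounds named here, this is the same kind of change as the one from compound 1 to compound 2, but the place differs: there the change sits two bonds along the chain from an aromatic nitrogen, here three bonds along. Given that the earlier step is a 1.4-fold lower number from compound 1 to compound 2 (0.16 log units; within the scatter), a step of the same size is expected, namely a 1.4-fold lower number from compound 3 to compound 4 (0.15 log units; within the scatter). Compound 4 is therefore estimated at 2300 nM, within a range from 1200 nM to 4600 nM.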

Compound 4, half-maximal inhibitory concentration: 1450 nM
Compound 4: middle estimate off by 1.6-fold (0.20 log units), on the high side, and the stated range covers the measured number.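

In this assay, putting (dimethylamino)methyl in place of diethylamino on the second core gives a 2.3-fold lower number from compound 3 to compound 4 (0.35 log units; beyond the scatter), a modest step that stands clear of the scatter. Set beside the earlier step, the change carries from one core to the other with no difference that can be told apart: the same change on two cores in this assay, a 1.4-fold lower number (0.16 log units; within the scatter) from compound 1 to compound 2 and a 2.3-fold lower number (0.35 log units; beyond the scatter) from compound 3 to compound 4, 1.6-fold (0.20 log units) apart, within the scatter of two such steps. This does not show that the step is truly larger on one core than on the other, and with a single pair on each core it says nothing about any further core; the place also differs, two bonds along the chain from an aromatic nitrogen in one pair and three bonds along in the other, so core and place cannot be separated.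

The compounds shown leave open whether a ring amine such as piperidine or morpholine at the end of the chain would follow the same course on both cores. Also open, on these data alone, is what a primary amine or a hydroxyl group in that place would give.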